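The source may hold more compounds than are shown below. What is called first, only, known or untested is meant among the compounds shown, and "the series" means these compounds.

compound 1 `O=C(O)CCC(=O)N1C/C(=C\c2ccccc2F)C(=O)/C(=C/c2ccccc2F)C1` gives 69000 nM
compound 2 `O=C(O)COCC(=O)N1C/C(=C\c2ccccc2F)C(=O)/C(=C/c2ccccc2F)C1` gives 310000 nM

In a functional assay on NCI-H441 cells (Homo sapiens) for antiproliferative activity, with a stated time of 24 h (a lower number here means a stronger inhibitor, a higher number a weaker inhibitor), compound 2 stands at 310000 nM as the higher of the two numbers, which makes it the weaker of the pair. Compound 3 `O=C(O)CCCC(=O)N1C/C(=C\c2ccccc2F)C(=O)/C(=C/c2ccccc2F)C1` carries 2-carboxyethyl in place of carboxymethoxy on a saturated chain carbon bound to a carbonyl carbon. For the measured compounds named here, the one measured step bearing on this is a 4.5-fold higher number from compound 1 to compound 2 (0.65 log units; beyond the scatter) and it is modest. At that step carboxymethoxy came in place of carboxymethyl at the same place, and in compound 3 carboxymethoxy leaves again. With compound 1 at 69000 nM as the guide, a lower number than that of compound 2 is expected in this assay for compound 3, by a step of similar size or somewhat smaller. One step is thin evidence, and 2-carboxyethyl has no measured value of its own in this set. The expected change is a 3.4-fold lower number from compound 2 to compound 3 (0.54 log units; beyond the scatter) and it rests on that single step. For compound 3 the estimate is 90000 nM with an expected range from 30000 nM to 250000 nM on this read-out.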

Compound 3, half-maximal inhibitory concentration: 60000 nM
Compound 3: middle estimate off by 1.5-fold (0.18 log units), on the high side; the range from low to high includes it.
By their numbers in this assay, from the lowest: compounds 3 and 1 (each within the scatter of the next); then compound 2.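

In this assay, 2-carboxyethyl in place of carboxymethoxy gives a 5.2-fold lower number from compound 2 to compound 3 (0.71 log units; beyond the scatter), and since both groups count 5 heavy atoms, the change at this position is an exchange of atoms at equal group size, 3 carbon and 2 oxygen against 2 carbon and 3 oxygen. Along the all-carbon chains, the further step reads a 1.2-fold lower number from compound 1 to compound 3 (0.06 log units; within the scatter) and stays within the scatter, so in this assay the 3-carboxypropyl and shorter acid chains of compound 3 and compound 1 cannot be told apart, while compound 2, the only carboxymethoxy member of the three, stands apart from both, and none of the three goes against this reading. Nothing shown here accounts for the separation of compound 2 from the other two.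

From the compounds shown here alone, what a longer chain, or an amine in place of the carboxylic acid, would do at this position stays open. For the compounds shown here, with only three compounds in this assay, it is also open whether the separation of compound 2 would carry over to a different aryl substitution on the shared core.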